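Swapping Trifluoromethyl for Cyclopropyl on One Aromatic Carbon

The source may report more compounds than this note shows. Statements on the series, on what has been measured and on what is new or still open speak of the compounds shown alone.

Compound 1 `CC(C)(O)c1cncc(-n2ncc3ccccc32)c1` and compound 2 `CC(C)(O)c1cncc(-n2nc(C(F)(F)F)c3ccccc32)c1` share one core and differ at a single aromatic carbon. Among the compounds with values here, in an assay on cells for inhibition of cytochrome P450 11B2, mitochondrial (Homo sapiens), read by HTRF, with stated times of 1 h and 3 h (a lower number here means a stronger inhibitor, a higher number a weaker inhibitor), compound 1 gives 15 nM, while compound 2 gives 300 nM, the higher of the two numbers measured so far. Within the data shown here, the only step known is a 20-fold higher number from compound 1 to compound 2 (1.30 log units; beyond the scatter). Compound 3 `CC(C)(O)c1cncc(-n2nc(C3CC3)c3ccccc32)c1` carries cyclopropyl in place of trifluoromethyl on an aromatic carbon. Among the measured compounds shown here, no measured step exchanges one group for another at this carbon, so that earlier step is only a rough guide, and little movement beyond the scatter is expected. The expected step is a 1.5-fold lower number from compound 2 to compound 3 (0.18 log units; within the scatter). Compound 3 is thus estimated at 200 nM, within 50 nM to 800 nM.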

Compound 3, half-maximal inhibitory concentration: 760 nM
Compound 3: middle estimate off by 3.8-fold (0.58 log units), on the low side; low and high end bracket the measured number.
By their numbers in this assay, from the lowest: compound 1; then compound 2; then compound 3.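

At this aromatic carbon, the two groups are not interchangeable: putting cyclopropyl in place of trifluoromethyl gives a 2.5-fold higher number from compound 2 to compound 3 (0.40 log units; beyond the scatter). Set against hydrogen, cyclopropyl gives a 51-fold higher number from compound 1 to compound 3 (1.70 log units; beyond the scatter), so among these three compounds hydrogen gives the lowest number and cyclopropyl the highest. No measurement at hand explains this order. As far as these compounds go, what remains open is whether any other group at this carbon, such as a methyl or an amine, could bring the number back down towards that of hydrogen.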